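A few compounds are considered here, and "the series" means these few. Any claim that something is new, unique, unknown or untested is made for them only; others in the source may bear on it.

Measured in a functional assay on MRC5 cells (Homo sapiens) for cytotoxicity; a lower number here means that less compound is tolerated, a higher number that more compound is tolerated:
- compound 1 `O=C(Cc1ccccc1)NNC(=O)c1ccc([N+](=O)[O-])o1` gives 2000 nM
- compound 2 `O=C(NNC(=O)c1cccc2ccccc12)c1ccc([N+](=O)[O-])o1` gives 1000 nM
- compound 3 `CC(C)(C)OC(=O)N[C@@H](C(=O)NNC(=O)c1ccc([N+](=O)[O-])o1)c1ccccc1` gives 6000 nM

Compound 3 carries the highest number of the three, and its gaps to both others lie beyond the scatter. The next step leads to compound 4 `N[C@@H](C(=O)NNC(=O)c1ccc([N+](=O)[O-])o1)c1ccccc1`, the change being (hydrogen in place of tert-butoxycarbonyl on an amine nitrogen). In words, this is hydrogen in place of tert-butoxycarbonyl on an amine nitrogen. Cut one bond further out, it reads (tert-butoxycarbonyl)amino to amino.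

Among the measured compounds shown here, one measured step bears on this: a 3.0-fold higher number from compound 1 to compound 3 (0.48 log units; beyond the scatter), with (tert-butoxycarbonyl)amino in place of hydrogen. It is modest but beyond the scatter. For the measured compounds named here, it is not the exact reverse of the new change, since compound 4 keeps an amino group where compound 1 has hydrogen, and no measured compound carries that free amino group. Part of the rise seen in that step may therefore be given back, which points to a modest move towards a lower number in this assay. The expected change is a 2.4-fold lower number from compound 3 to compound 4 (0.38 log units; beyond the scatter), and it remains uncertain on a single step. For compound 4 the estimated value is 2500 nM, with an expected range of 800 nM to 10000 nM.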

Compound 4, half-maximal cytotoxic concentration: 14000 nM
The estimate for compound 4 lay 5.6-fold (0.75 log units) below the measured number; the measured number lies above the stated range.
By their numbers in this assay, from the lowest: compounds 2 and 1 (each within the scatter of the next); then compound 3; then compound 4.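

In this assay, among the compounds shown here, the earlier compounds left it unclear whether the rise over the hydrogen of compound 1 depended on the tert-butoxycarbonyl group, and the new result shows that it does not: taking that group off the amine nitrogen gives a 2.3-fold higher number from compound 3 to compound 4 (0.37 log units; beyond the scatter) instead of a return towards compound 1. On the saturated chain carbon bound to an aromatic carbon and a carbonyl carbon, the free amino group in place of hydrogen gives a 7.0-fold higher number from compound 1 to compound 4 (0.85 log units; beyond the scatter), so both substituted compounds read higher than compound 1, and within this pair the tert-butoxycarbonyl group goes with the lower number. Nothing at hand accounts for either step, and no independent measurement bears on them.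

The compounds shown do not tell whether the higher number needs a free amine at this carbon, since a methylamino, dimethylamino, acetylamino or hydroxyl group there has no value among them. They also leave open whether the same amino group on the chain carbon would give a similar step with a naphthalene-bearing compound such as compound 2, which has no such chain carbon.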